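The source may hold more compounds than are shown below. What is called first, only, known or untested is meant among the compounds shown, and "the series" means these compounds.

Measured compounds and their values:
- Compound 1, `COc1ccc(C2=NN(c3ccc(S(C)(=O)=O)cc3)C(=O)CC2)cc1`: 46.7%
- Compound 2, `Cc1cc(C2=NN(c3ccc(S(C)(=O)=O)cc3)C(=O)CC2)ccc1O`: 26.6%
- Compound 3, `CS(=O)(=O)c1ccc(N2N=C(c3ccccc3)CCC2=O)cc1`: 26.6%

These three compounds were tested in a functional assay on the whole organism (strain Wistar) for inhibition, with Rattus norvegicus as the target, read by paw edema, with stated times of 30 min and 3 h, at a dose of 0.05 mmol/kg by the oral route; a lower number here means less inhibition, a higher number more inhibition at the dose given (going by the name of the read-out). Compound 3 stands level with compound 2 at the digits given; the two together are the lowest of the three numbers, and compound 1 sits a step above them, as a number 20.1 percentage points lower from compound 1 to compound 3 (beyond the scatter) shows.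

Compound 4, `CCc1ccc(C2=NN(c3ccc(S(C)(=O)=O)cc3)C(=O)CC2)cc1`, has not yet been measured. It differs from compound 3 in one place: ethyl in place of hydrogen on an aromatic carbon. The aromatic ring that is bare in compound 3 carries this group para to a large group.

Going by the values given here, two measured steps touch this kind of change. Removing the methoxy group from compound 1 gave a number 20.1 percentage points lower from compound 1 to compound 3 (beyond the scatter), a drop beyond the scatter, so adding a group at that position of the ring once raised the number. Exchanging 4-hydroxy-3-methylphenyl for plain phenyl gave no change at the digits printed from compound 2 to compound 3 (within the scatter), no change at all. One substituent helped and one did not, and ethyl is a different group from either, so the expectation is a modest rise at best, with wide uncertainty.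

The estimated step is a number 9.4 percentage points higher from compound 3 to compound 4 (within the scatter). Compound 4 is therefore expected to give about 36%, between 20% and 52%.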

Compound 4, a percentage reported as inhibition, in the whole organism at one dose (the size of the read-out at that dose, not a potency): 46.7%
For compound 4 the middle estimate is 10.7 percentage points below the measured one; the range from low to high includes it.
By their numbers in this assay, from the lowest: compounds 2 and 3 (each within the scatter of the next); then compounds 1 and 4 (each within the scatter of the next).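

In this assay, going by these compounds alone, the ethyl group on the bare phenyl ring, para to a large group, gives a number 20.1 percentage points higher from compound 3 to compound 4 (beyond the scatter), so methoxy is no longer the only group seen to lift the number from this place. Ethyl, which counts no hydrogen-bond donors or acceptors, also matches methoxy, with no change at the digits printed from compound 1 to compound 4 (within the scatter), so an oxygen atom attached to the ring at this place is not needed to reach this level of inhibition. The step of a number 20.1 percentage points higher from compound 2 to compound 4 (beyond the scatter) adds a limit, since a substituted ring does not by itself give the higher number: compound 2 goes against any such rule, as it stays level with the unsubstituted compound 3.

No measurement among these data explains why ethyl and methoxy give the same reading or why the 4-hydroxy-3-methylphenyl ring does not. It remains open whether a longer chain such as propyl, or an amine, at this place would hold, raise or lower the number, and a reading at one dose gives no potency for any of these compounds.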